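Replacing the Amino Group of Compound 2

The compounds below may be only part of what the source reports. "The series", "measured", "known", "first", "only" and "open" are said of these compounds alone.

In a functional assay on KB cells (nasopharynx, Homo sapiens) for antiproliferative activity (on this read-out higher numbers stand for weaker inhibition and lower numbers for stronger inhibition), compound 1 `COc1ccc(S(=O)(=O)Nc2cccc3c(Cl)c[nH]c23)cc1` gives 0.55 ug/mL, and compound 2 `Nc1ccc(S(=O)(=O)Nc2cccc3c(Cl)c[nH]c23)cc1` gives 10 ug/mL. Compound 2 therefore holds the higher of the two numbers, which makes it the weaker inhibitor of this pair.

The next structure, compound 3 `NS(=O)(=O)Cc1ccc(S(=O)(=O)Nc2cccc3c(Cl)c[nH]c23)cc1`, has sulfamoylmethyl in place of amino on an aromatic carbon, para to a large group (sulfamoylmethyl in place of amino on an aromatic carbon). The amino group is the very group that compound 2 gained over compound 1, and one measured step bears on its removal: an 18-fold higher number from compound 1 to compound 2 (1.26 log units; beyond the scatter). Among the measured compounds shown here, that large step is the only guide, as no measured compound carries sulfamoylmethyl, and a methoxy result cannot simply be transferred to a different group. With the amino group gone, a partial return toward the number of compound 1 at 0.55 ug/mL is expected, though not all the way. The expected change is a 6.7-fold lower number from compound 2 to compound 3 (0.82 log units; beyond the scatter), pointing toward stronger inhibition in this assay. For compound 3 the estimated value is 1.5 ug/mL, with an expected range from 0.3 ug/mL to 8 ug/mL.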

Compound 3, half-maximal inhibitory concentration: 13 ug/mL
Compound 3: the middle estimate sits 8.7-fold (0.94 log units) below what was measured; the measured number lies above the stated range.
By their numbers in this assay, from the lowest: compound 1; then compounds 2 and 3 (each within the scatter of the next).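

In this assay, putting sulfamoylmethyl, with 5 heavy atoms, in place of the single heavy atom of amino gives a 1.3-fold higher number from compound 2 to compound 3 (0.11 log units; within the scatter), so compounds 2 and 3 cannot be told apart even though the two groups differ considerably in size. Taking the amino group away therefore does not by itself bring the number back towards that of compound 1: the comparison with methoxy gives a 24-fold higher number from compound 1 to compound 3 (1.37 log units; beyond the scatter), so at this aromatic carbon, methoxy now stands apart from two quite different replacements rather than one. Nothing measured here explains why amino and sulfamoylmethyl give numbers within the scatter of each other, or why methoxy differs from both.

The three compounds leave open whether the low number of compound 1 belongs to methoxy in particular or would also be seen with close relatives at the same carbon, such as ethoxy, methyl or a chlorine atom. They also cannot show how a carboxylic acid or a sulfamoyl group attached directly to the ring would compare with amino and sulfamoylmethyl.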